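This account rests on a few compounds, and the source may have more. Where it says the series, first, only, none or still open, it means among the compounds named here.

Compound 2 `O=C(/C=C/c1ccc(OCc2cn(Cc3ccc(Br)cc3)nn2)cc1)c1ccc([N+](=O)[O-])cc1` is measured in a functional assay on MCF7 cells (Homo sapiens) for inhibition, read by MTT assay, with a stated time of 48 h, tested at 10 uM (a higher number here means more inhibition of growth at the concentration tested, a lower number less inhibition of growth), and gives 18%. Going by the values given here, it has the highest of the two numbers reported so far, but its only neighbour, compound 1 `O=C(/C=C/c1ccc(OCc2cn(Cc3cccc(Br)c3)nn2)cc1)c1ccc([N+](=O)[O-])cc1`, which in this assay gives 12%, lies close: the change of a number 6 percentage points higher from compound 1 to compound 2 (within the scatter), the 4-bromophenyl replacing the 3-bromophenyl on a saturated chain carbon bound to an aromatic nitrogen, stays within the scatter. Compound 3 `O=C(/C=C/c1ccc(OCc2cn(Cc3cccc(F)c3)nn2)cc1)c1ccc([N+](=O)[O-])cc1` differs from compound 2 by 3-fluorophenyl in place of 4-bromophenyl on a saturated chain carbon bound to an aromatic nitrogen. Among the compounds with values here, the only measured step concerns a shift of the bromine around that ring and left this assay essentially unchanged; no measured step addresses a bromine giving way to a fluorine. On this basis compound 3 is expected to behave much like compound 2, with a step of a number 5 percentage points lower from compound 2 to compound 3 (within the scatter) that stays within the scatter. Compound 3 is therefore estimated at 13% in this assay, within a range from 2% to 26%.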

Compound 3, percent growth inhibition at one concentration: 30%
For compound 3 the middle estimate is 17 percentage points below the measured one, outside the stated range (above it).
By their numbers in this assay, from the lowest: compounds 1 and 2 (each within the scatter of the next); then compound 3.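

In this assay the exchange at this position is no longer silent: 3-fluorophenyl in place of 4-bromophenyl gives a number 12 percentage points higher from compound 2 to compound 3 (beyond the scatter) and thus a difference that the shift of the bromine alone had not produced. The comparison with the ring that also carries its halogen as a 3-substituted phenyl is the more direct one, since fluoro in place of bromo on an aromatic carbon is the only change and gives a number 18 percentage points higher from compound 1 to compound 3 (beyond the scatter), so among these compounds the halogen exchange alone is enough for a step beyond the scatter. Nothing available explains this difference.

The compounds shown leave open whether fluorine itself matters or only the absence of bromine, which an unsubstituted phenyl or a 3-chlorophenyl would address. Also open, from the compounds shown here alone, are how a 4-fluorophenyl would compare and whether an amine or a carboxylic acid on this ring would be tolerated.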